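A few compounds are considered here, and "the series" means these few. Any claim that something is new, unique, unknown or untested is made for them only; others in the source may bear on it.

Measured in a physicochemical assay for lipophilicity, using the shake flask method, in phosphate buffer, measured as octanol-water partition, with a stated time of 30 min, at pH 7.4; a higher number here means a more lipophilic compound, a lower number a more polar compound:
- compound 1 `O=C1c2ccccc2CN1c1cnc(NCc2c(F)ccc3c2CCO3)n2cnnc12`: 2.7
- compound 2 `CC1(C)CC(=O)N(c2cnc(NCc3c(F)ccc4c3CCO4)n3cnnc23)C1`: 2
- compound 3 `CN(C(=O)c1ccccc1)c1cnc(NCc2c(F)ccc3c2CCO3)n2cnnc12`: 2.4

Compound 3 stands at 2.4. The step of a number 0.30 log units lower from compound 1 to compound 3 (within the scatter) cannot be told from scatter, whereas the step of a number 0.40 log units higher from compound 2 to compound 3 (beyond the scatter) can.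

Compound 4 `C[C@H]1CC(=O)N(c2cnc(NCc3c(F)ccc4c3CCO4)n3cnnc23)C1` carries 4-methyl-2-oxopyrrolidin-1-yl in place of benzoyl(methyl)amino on an aromatic carbon. The closest guide is compound 2, whose 4,4-dimethyl-2-oxopyrrolidin-1-yl has the same ring. Its step to benzoyl(methyl)amino was a number 0.40 log units higher from compound 2 to compound 3 (beyond the scatter), and the step of a number 0.70 log units lower from compound 1 to compound 2 (beyond the scatter) also ends at that ring. The group in compound 4 is smaller still, so a modest drop, somewhat larger than the first of those steps, seems likely. The expected step is a number 0.70 log units lower from compound 3 to compound 4 (beyond the scatter). Compound 4 is estimated at 1.7, with an expected range from 1.3 to 2.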

Compound 4, distribution coefficient: 1.8
Estimate against measurement, compound 4: 0.10 log units below, and the stated range covers the measured number.
By their numbers in this assay, from the lowest: compounds 4 and 2 (each within the scatter of the next); then compounds 3 and 1 (each within the scatter of the next).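

In this assay, this position separates the two groups with a six-membered aromatic ring from 4-methyl-2-oxopyrrolidin-1-yl: the steps are a number 0.60 log units lower from compound 3 to compound 4 (beyond the scatter) and a number 0.90 log units lower from compound 1 to compound 4 (beyond the scatter). Within the same ring, dropping one of the two methyl groups gives a number 0.20 log units lower from compound 2 to compound 4 (within the scatter), so that change cannot be read as a real shift. No measurement shown here explains these steps. Where the 2-oxopyrrolidin-1-yl ring with no methyl, or an amine such as morpholin-4-yl, would stand remains open, as does the mirror-image form of the methyl compound.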